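Fluoro to dimethylamino on a weakly inhibiting core

The source may report more compounds than this note shows. Statements on the series, on what has been measured and on what is new or still open speak of the compounds shown alone.

In a functional assay on CAKI-1 cells (Homo sapiens) for inhibition (on this read-out higher numbers stand for weaker inhibition of growth and lower numbers for stronger inhibition of growth), compound 1 `NS(=O)(=O)c1ccc(/C=C/c2ccc(F)cc2)cc1` gives 36300 nM and compound 2 `NS(=O)(=O)c1ccc(/C=C/c2cccc(O)c2)cc1` gives 50200 nM, so the two stand within the scatter of each other. Compound 3 `CN(C)c1ccc(/C=C/c2ccc(S(N)(=O)=O)cc2)cc1` has dimethylamino in place of fluoro on an aromatic carbon, para to a large group: dimethylamino in place of fluoro on an aromatic carbon. For the measured compounds named here, no measured pair shows what this exchange does, so no change beyond the scatter is expected in this assay. The estimated step, a 1.2-fold lower number from compound 1 to compound 3 (0.08 log units; within the scatter), stays within the scatter. Compound 3 is expected at 30000 nM, with an estimated range of 9000 nM to 80000 nM.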

Compound 3, concentration for 50% growth inhibition: 50300 nM
Estimate against measurement, compound 3: 1.7-fold (0.22 log units) below; measured number inside the range.
By their numbers in this assay, from the lowest: compounds 1, 2 and 3 (each within the scatter of the next).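

In this assay, for the compounds shown here, dimethylamino in place of fluoro on an aromatic carbon, para to a large group, gives a 1.4-fold higher number from compound 1 to compound 3 (0.14 log units; within the scatter), the first measured pair for this exchange. On the shared core, this position therefore takes a group of 3 heavy atoms, including a hydrogen-bond acceptor, in place of a single fluorine with no change beyond the scatter. Nothing at hand explains this result.

On these data alone, what a carboxylic acid or a longer chain on this carbon would do stays open, and so does whether any group here can move the number beyond the scatter.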